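Chloro in place of fluoro on compound 2

A few compounds are considered here, and "the series" means these few. Any claim that something is new, unique, unknown or untested is made for them only; others in the source may bear on it.

Among the measured compounds shown here, in a functional assay on HL-60 cells (Homo sapiens) for cytotoxicity, read by MTT assay (on this read-out higher numbers stand for weaker inhibition and lower numbers for stronger inhibition), compound 2 `CC(NS(=O)(=O)c1ccc(F)cc1)C1=CC(=O)c2c(O)ccc(O)c2C1=O` gives 90 nM and stands highest of the two numbers so far, while compound 1 `COc1ccc(S(=O)(=O)NC(C)C2=CC(=O)c3c(O)ccc(O)c3C2=O)cc1` gives 20 nM as the lower one. Compound 3 `CC(NS(=O)(=O)c1ccc(Cl)cc1)C1=CC(=O)c2c(O)ccc(O)c2C1=O` has chloro in place of fluoro on an aromatic carbon, para to a large group, counted as chloro in place of fluoro on an aromatic carbon for this change. For the measured compounds named here, the one measured step at this place is a 4.5-fold higher number from compound 1 to compound 2 (0.65 log units; beyond the scatter) for fluoro in place of methoxy. A smaller step towards a lower number is expected here, and it may stay within the scatter. The estimated step is a 1.5-fold lower number from compound 2 to compound 3 (0.18 log units; within the scatter) on present data. For compound 3 the estimated value is 60 nM with an expected range of 25 nM to 170 nM in this read-out.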

Compound 3, half-maximal inhibitory concentration: 250 nM
Compound 3: the middle estimate sits 4.2-fold (0.62 log units) below what was measured; measured number outside the range, above it.
By their numbers in this assay, from the lowest: compound 1; then compound 2; then compound 3.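

In this assay, the halogen at this position matters: 4-fluorophenyl to 4-chlorophenyl gives a 2.8-fold higher number from compound 2 to compound 3 (0.44 log units; beyond the scatter) and is not a neutral exchange. Chloro in place of methoxy gives a 13-fold higher number from compound 1 to compound 3 (1.10 log units; beyond the scatter) and widens the span at this single position, so the three compounds now run methoxy, fluoro, chloro from lowest number to highest. No data on hand account for this order.

Going by these compounds, whether the order extends to bromo, an amine or a carboxylic acid on the same aromatic carbon remains open. So does whether it holds with the group at another carbon of that ring.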